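Nitro group placement on the aryl ester of compound 1

The source may report more compounds than this note shows. Statements on the series, on what has been measured and on what is new or still open speak of the compounds shown alone.

Compound 1 `CC1=CC[C@H](C(C)C)c2cc(C)c(OC(=O)c3ccc([N+](=O)[O-])cc3)cc21` is one of three aryl esters of the shared core. In a functional assay on K562 cells (Homo sapiens) for antiproliferative activity, read by sulforhodamine B assay, with a stated time of 48 h, tested at 50 uM (on this read-out lower numbers stand for less inhibition and higher numbers for more inhibition at the one concentration tested (going by the name of the read-out)), compound 1 gives 89%, the second highest of the three numbers. Compound 3 `Cc1cc2c(C(C)C)ccc(C)c2cc1OC(=O)c1ccc([N+](=O)[O-])cc1`, which carries the same 4-nitrophenyl group on a closely related core, gives 100%, and the gap from compound 1 to compound 3 lies beyond the scatter. Compound 2 `COc1cccc(C(=O)Oc2cc3c(C)ccc(C(C)C)c3cc2C)c1`, with 3-methoxyphenyl on the carbonyl carbon, gives 14.2%, far below compound 1.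

Compound 4 `CC1=CC[C@H](C(C)C)c2cc(C)c(OC(=O)c3cccc([N+](=O)[O-])c3)cc21` is the next candidate: 3-nitrophenyl in place of 4-nitrophenyl on a carbonyl carbon. Among the compounds with values here, the only measured step, a number 85.8 percentage points higher from compound 2 to compound 3 (beyond the scatter), exchanges both the substituent and where it sits, so it does not isolate the shift from 4-nitrophenyl to 3-nitrophenyl; no measured pair tests that shift alone. It does show that the aryl group on the carbonyl carbon can swing the read-out across almost its whole range. Compound 4 keeps a nitrophenyl ester, and its number is expected to stay nearer compound 1 than compound 2, with a real chance of some loss. The step of a number 19 percentage points lower from compound 1 to compound 4 (beyond the scatter) is expected to be modest and downward, with wide uncertainty. Compound 4 is estimated at 70%, within 30% to 95%.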

Compound 4, a percentage reported as inhibition, at one concentration (the size of the read-out at that concentration, not a potency): 15.9%
Estimate against measurement, compound 4: 54.1 percentage points above, and the stated range ends above it.
By their numbers in this assay, from the lowest: compounds 2 and 4 (each within the scatter of the next); then compound 1; then compound 3.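

Within the data shown here, on the shared core, in this assay, 3-nitrophenyl in place of 4-nitrophenyl on a carbonyl carbon gives a number 73.1 percentage points lower from compound 1 to compound 4 (beyond the scatter) and is the first measured pair to isolate this shift. The earlier a number 85.8 percentage points higher from compound 2 to compound 3 (beyond the scatter) changed both the substituent and where it sits, whereas here the leaving and entering groups have the same atoms and the same counts, so a nitrophenyl ester alone does not hold the read-out high, and for this pair the place of the nitro group on the ring is the only difference. Nothing measured here gives a cause for this loss.

Whether the same shift has a similar effect on the core of compound 3 stays open, as the compounds shown include no 3-nitrophenyl ester on that core. Also open, from the compounds shown here alone, is whether an amine or a carboxylic acid in place of the nitro group of the 4-nitrophenyl group would keep the read-out of compound 1, and the single concentration tested says nothing about potency across a range of concentrations.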